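Alkoxy-to-thioether swap on the pyridine of compound 1

The source may report more compounds than this note shows. Statements on the series, on what has been measured and on what is new or still open speak of the compounds shown alone.

Measured compounds:
- compound 1, `COc1cc([C@](O)(CCN(C)C)[C@@H](c2cc3cc(Br)ccc3nc2OC)c2ccnc(OC)c2OC)cc(OC(C)C)n1`: 6.7 uL/min
- compound 2, `COc1cc([C@](O)(CCN(C)C)[C@@H](c2cc3cc(Br)ccc3nc2OC)c2ccnc(OC)c2OC)cc(OC2CCC2)n1`: 4.6 uL/min
- compound 3, `CCOc1cc([C@](O)(CCN(C)C)[C@@H](c2cc3cc(Br)ccc3nc2OC)c2ccnc(OC)c2OC)cc(OC(C)C)n1`: 1.6 uL/min

In an ADME assay on microsomes from liver (Mus musculus) for metabolic stability (on this read-out higher numbers stand for fast clearance and lower numbers for slow clearance), compound 1 gives the highest of the three numbers. Its nearest neighbour is compound 2, a 1.5-fold lower number from compound 1 to compound 2 (0.16 log units; within the scatter), a step that stays within the scatter. The wider gap is to compound 3, a 4.2-fold lower number from compound 1 to compound 3 (0.62 log units; beyond the scatter), which lies beyond the scatter.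

Compound 4, `COc1nc2ccc(Br)cc2cc1[C@@H](c1ccnc(OC)c1OC)[C@@](O)(CCN(C)C)c1cc(SC)nc(SC)c1`, has not yet been measured. It differs from compound 1 as follows: a group of 10 heavy atoms (7 carbon, 1 nitrogen, 2 sulfur; one six-membered aromatic ring with 1 hetero atom) in place of a group of 12 heavy atoms (9 carbon, 1 nitrogen, 2 oxygen; one six-membered aromatic ring with 1 hetero atom), on a saturated chain carbon bound to an oxygen on a saturated carbon and two saturated chain carbons. Neither measured step covers this change. Within the data shown here, both steps touch the same ring, but each alters only one of its alkoxy groups, whereas here the whole ring with both of its substituents is exchanged for a ring bearing two thioethers. Among the measured compounds shown here, with no direct precedent, the expectation is a number close to compound 1 but with broad uncertainty in either direction. The step from compound 1 to compound 4 is therefore expected to be a 1.2-fold higher number from compound 1 to compound 4 (0.08 log units; within the scatter). For compound 4 the estimated value in this assay is 8 uL/min, with a range of 2.5 uL/min to 25 uL/min.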

Compound 4, intrinsic clearance in a liver preparation (reported as CLH), per the amount of preparation that the assay uses: 10 uL/min
The estimate for compound 4 lay 1.3-fold (0.10 log units) below the measured number; the measured number falls inside the stated range.
By their numbers in this assay, from the lowest: compound 3; then compounds 2, 1 and 4 (each within the scatter of the next, the first and the last beyond it).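

In this assay the exchange of the whole ring for one bearing two thioethers gives a 1.5-fold higher number from compound 1 to compound 4 (0.17 log units; within the scatter), so this position accepts sulfur in place of oxygen on both substituents at once without a step beyond the scatter. Among the steps on this ring, the single-place change giving a 4.2-fold lower number from compound 1 to compound 3 (0.62 log units; beyond the scatter) remains the only one beyond the scatter, and it leads to a lower number, whereas the exchange to compound 4 does not separate from compound 1. No measurement at hand bears on why the exchange behaves this way.

Both substituents differ together in compound 4, so the share of each thioether in this step stays unresolved. Going by these compounds, how this read-out responds to a ring carrying an amine or a carboxylic acid at these places also remains open.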